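The source may hold more compounds than are shown below. What is called first, only, known or untested is meant among the compounds shown, and "the series" means these compounds.

In a functional assay on brain (Rattus norvegicus, strain Wistar) for inhibition (on this read-out lower numbers stand for stronger inhibition and higher numbers for weaker inhibition), the measured compounds stand as follows:

Compound 1, `CCCCCCCCCCc1ccc(-c2c(C)[nH]c(=O)n2C2CCCCC2)cc1`: 27000 nM
Compound 2, `CCCCCCCCCCOc1ccc(-c2c(C)[nH]c(=O)n2C2CCCCC2)cc1`: 10500 nM
Compound 3, `CCCCCCCCCCCCc1ccc(-c2c(C)[nH]c(=O)n2C2CCCCC2)cc1`: reaches only the limit of this assay, > 100000 nM

Compound 1 and compound 3 differ in one place: ethyl in place of hydrogen on a saturated chain carbon, ten or more bonds along the chain from an aromatic carbon. This change gave an at least 3.7-fold higher number from compound 1 to compound 3 (0.56 log units; beyond the scatter). Because the value of compound 3 sits at the limit of > 100000 nM in this assay, at which 1 of the 3 values shown sits, the full size of that step is not known, only that it is at least as large as stated.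

Compound 2 carries a different core from compound 1; the difference between the two cores is not broken down here. Compound 2 holds the lowest of the two plain numbers, with compound 1 a step beyond the scatter away.

The unmeasured compound 4, `CCCCCCCCCCCCOc1ccc(-c2c(C)[nH]c(=O)n2C2CCCCC2)cc1`, differs from compound 2 in the same kind of change: ethyl in place of hydrogen on a saturated chain carbon, ten or more bonds along the chain from an oxygen on an aromatic ring. Around the place the two descriptions differ in their words: in the first pair the chain is counted from an aromatic carbon, in the second from an oxygen on an aromatic ring. Since the same lengthening of the chain by ethyl on compound 1 gave a step of at least modest size, the same kind of change on compound 2 is expected to raise the number as well. Compound 4 is therefore expected to give 40000 nM in this assay, between 15000 nM and 150000 nM. For compound 4 this estimate means a 3.8-fold higher number from compound 2 to compound 4 (0.58 log units; beyond the scatter), a step resting on the measured at least 3.7-fold higher number from compound 1 to compound 3 (0.56 log units; beyond the scatter).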

Compound 4, half-maximal inhibitory concentration: 52400 nM
The estimate for compound 4 lay 1.3-fold (0.12 log units) below the measured number; measured number inside the range.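

In this assay, ethyl in place of hydrogen on a saturated chain carbon, ten or more bonds along the chain from an oxygen on an aromatic ring, gave a 5.0-fold higher number from compound 2 to compound 4 (0.70 log units; beyond the scatter), so the number also rose on the core of compound 2. Set beside the earlier step, this shows that the change points the same way on both cores, while a comparison of its size stays unsettled: the same change on two cores in this assay, an at least 3.7-fold higher number (0.56 log units; beyond the scatter) from compound 1 to compound 3 and a 5.0-fold higher number (0.70 log units; beyond the scatter) from compound 2 to compound 4; the limit leaves it open whether they differ. The agreement therefore holds for direction only, for this one change and these two cores, and it gives no measure of how exactly the size of the step carries from one core to the other, as the value of compound 3 is a limit and not a number: the limit of > 100000 nM in this assay, at which 1 of the 4 values shown sits.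

The compounds shown leave open how the number would move with a shorter chain or a longer chain on either core, and so whether the rise seen here continues. They also leave open what an amine or a carboxylic acid in place of the added ethyl would do in this series.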